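Losing the carbonyl from the most potent compound so far

This account rests on a few compounds, and the source may have more. Where it says the series, first, only, none or still open, it means among the compounds named here.

Compound 1 `COc1ccc(S(=O)(=O)N2CCc3cccc(NC(=O)c4ccc([N+](=O)[O-])cc4)c32)cc1`: 65 nM
Compound 2 `COc1ccc(S(=O)(=O)N2CCc3cccc(NC(=O)c4ccncc4)c32)cc1`: 8.6 nM

In a functional assay on HT-29 cells (Homo sapiens) for cytotoxicity (a lower number here means a stronger inhibitor, a higher number a weaker inhibitor), compound 2 holds the lower of the two numbers. Compound 3 `COc1ccc(S(=O)(=O)N2CCc3cccc(NCc4ccccc4)c32)cc1` has benzyl in place of (pyridin-4-yl)carbonyl on a nitrogen on an aromatic ring. Going by the values given here, only one measured step bears on this change, and only in part: a 7.6-fold lower number from compound 1 to compound 2 (0.88 log units; beyond the scatter), with pyridin-4-yl in place of 4-nitrophenyl on a carbonyl carbon. Among the compounds with values here, that step shows the number moving with the group on the carbonyl, but no measured compound lacks the carbonyl, so its removal is untested. Starting from compound 2 at 8.6 nM, a higher number is expected, by a step of similar or greater size, with wide uncertainty. The estimated change is a 14-fold higher number from compound 2 to compound 3 (1.14 log units; beyond the scatter). For compound 3 the expected value is 120 nM, with an estimated range from 20 nM to 700 nM.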

Compound 3, half-maximal inhibitory concentration: > 10000 nM
Compound 3: no number, only a limit; the forecaster's own chance of this, stated with the estimate: 5%; at least 83-fold (1.92 log units) between middle value and limit.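

In this assay compound 3 gives > 10000 nM, which is a limit of the assay and not a number. Exchanging (pyridin-4-yl)carbonyl for benzyl on this nitrogen gives an at least 1100-fold higher number from compound 2 to compound 3 (3.06 log units; beyond the scatter), a far larger move than a 7.6-fold lower number from compound 1 to compound 2 (0.88 log units; beyond the scatter), which came from changing only the group on the carbonyl. Among the three compounds, then, measurable potency appears only in the two that keep a carbonyl on this nitrogen, and the group on that carbonyl only tunes the number.

The change removes the carbonyl and the ring nitrogen together, so the compounds shown do not say which of the two accounts for the loss. A plain benzoyl group or a pyridin-4-ylmethyl group on this nitrogen would separate the two.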